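Adding Bromo to a Weak Benzyl Ether Inhibitor

This account rests on a few compounds, and the source may have more. Where it says the series, first, only, none or still open, it means among the compounds named here.

In an assay on isolated protein for inhibition of Amine oxidase [flavin-containing] B (Homo sapiens), read by fluorescence, with a stated time of 20 min (on this read-out lower numbers stand for stronger inhibition and higher numbers for weaker inhibition), compound 1 `CC(=O)c1cc(OCc2ccc(Br)cc2)ccc1O` gives 172 nM, while compound 2 `O=c1ccoc2cccc(OCc3ccccc3)c12` gives 8030 nM. Compound 2 thus holds the higher of the two numbers, and its gap from compound 1 lies beyond the usual scatter. Compound 3 `O=c1ccoc2cccc(OCc3ccc(Br)cc3)c12` keeps the core of compound 2 and differs from it only by bromo in place of hydrogen on an aromatic carbon. Among the compounds with values here, no measured pair isolates this change; compound 1, which also carries a bromo group, gives 172 nM but sits on a different core. A modest drop is expected, as the estimated step of a 3.2-fold lower number from compound 2 to compound 3 (0.51 log units; beyond the scatter). Compound 3 is therefore expected at 2500 nM, within 600 nM to 8000 nM.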

Compound 3, half-maximal inhibitory concentration: 4340 nM
Compound 3: middle estimate off by 1.7-fold (0.24 log units), on the low side; the measured number falls inside the stated range.
By their numbers in this assay, from the lowest: compound 1; then compounds 3 and 2 (each within the scatter of the next).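

Bromo in place of hydrogen on an aromatic carbon, para to a large group, gives a 1.9-fold lower number from compound 2 to compound 3 (0.27 log units; within the scatter) in this assay, so on this core the two compounds cannot be told apart. Within the data shown here, this is the only pair here that isolates the change, and it reads the swap directly on one core. No measurement offered here explains the result.

As far as these compounds go, whether an amine or a carboxylic acid at the same place would give a number beyond the scatter stays open. So does what the same swap would do on the core of compound 1.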